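The source may hold more compounds than are shown below. What is called first, only, known or untested is meant among the compounds shown, and "the series" means these compounds.

Compound 3, with the structure `COc1ccc(-c2nn(-c3ccccc3)cc2C(=O)NCc2cn(Cc3ccc(OC)c(OC)c3)nn2)cc1`, is the weakest-characterised member of this small set: in a functional assay on MCF7 cells (Homo sapiens) for antiproliferative activity, read by sulforhodamine B assay, with a stated time of 48 h (a higher number here means a weaker inhibitor of growth, a lower number a stronger inhibitor of growth), compound 3 returns only the limit > 100000 nM, so no number is known for it. The two compounds that do carry numbers share the 3,5-dimethoxybenzyl group on the triazole. Compound 1, `COc1cc(Cn2cc(CNC(=O)c3cn(-c4ccccc4)nc3-c3ccccc3)nn2)cc(OC)c1`, gives 2400 nM in this assay. Compound 2, `COc1cc(Cn2cc(CNC(=O)c3cn(-c4ccccc4)nc3-c3ccc(Cl)cc3)nn2)cc(OC)c1`, gives 150 nM in this assay. Among the measured compounds shown here, the single measured step, a 16-fold lower number from compound 1 to compound 2 (1.20 log units; beyond the scatter), concerns a chloro in place of hydrogen on an aromatic carbon and says nothing about the benzyl group itself; the limit line the limit of > 100000 nM in this assay, at which 1 of the 3 values shown sits, is the only further evidence, and it is a limit, not a cause.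

Compound 4, `COc1ccc(-c2nn(-c3ccccc3)cc2C(=O)NCc2cn(Cc3cc(OC)cc(OC)c3)nn2)cc1`, is reached from compound 3 by the change (3,5-dimethoxyphenyl in place of 3,4-dimethoxyphenyl on a saturated chain carbon bound to an aromatic nitrogen), that is, 3,5-dimethoxyphenyl in place of 3,4-dimethoxyphenyl on a saturated chain carbon bound to an aromatic nitrogen. For the measured compounds named here, no measured step bears directly on this exchange. Going by the values given here, compound 4 keeps the 4-methoxyphenyl of compound 3 on the core, which no measured compound carries, while taking up the benzyl group that compounds 1 and 2 share. Compound 4 is therefore expected to fall between these situations, with the step of an at least 10-fold lower number from compound 3 to compound 4 (1.00 log units; beyond the scatter) estimated only loosely. The estimate for compound 4 in this assay is 10000 nM, within 1000 nM to 100000 nM.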

Compound 4, concentration for 50% growth inhibition: 700 nM
Beside the measured number, compound 4's estimate is 14-fold (1.15 log units) above it; measured number below the stated range.
By their numbers in this assay, from the lowest: compound 2; then compound 4; then compound 1. At a limit, above all of these: compound 3.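

In this assay, among the compounds shown here, the exchange of 3,4-dimethoxyphenyl for 3,5-dimethoxyphenyl on a saturated chain carbon bound to an aromatic nitrogen turns out to be a large change, and it is the only measured step at this position (an at least 140-fold lower number from compound 3 to compound 4 (2.15 log units; beyond the scatter)). With the 3,5-dimethoxybenzyl group held constant, compound 4 also adds a third substituent to the comparison of hydrogen and chloro on the aromatic carbon of the core, with methoxy improving on hydrogen (a 3.4-fold lower number from compound 1 to compound 4 (0.54 log units; beyond the scatter)) but falling short of chloro (a 4.7-fold higher number from compound 2 to compound 4 (0.67 log units; beyond the scatter)). Going by these compounds, the true size of the step at the benzyl position remains unknown, as compound 3 is held only at a limit and not at a number: (the limit of > 100000 nM in this assay, at which 1 of the 4 values shown sits).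

The compounds shown leave open whether the 3,4-dimethoxybenzyl group would cost as much when the aromatic carbon of the core carries hydrogen or chloro in place of methoxy. They also leave open how an unsubstituted benzyl, a 3-methoxybenzyl or a 3,4,5-trimethoxybenzyl group would compare with the 3,5-dimethoxybenzyl group at this position.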